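Cyclobutylmethyl in place of isobutyl on compound 2

The compounds below may be only part of what the source reports. "The series", "measured", "known", "first", "only" and "open" are said of these compounds alone.

In an in vitro ADME assay on microsomes from liver (Rattus norvegicus) for metabolic stability, read by LC-MS, using NADPH, tested at 1 uM (a higher number here means that the compound lasts longer, a lower number that the compound disappears faster), compound 2 (`CC(C)CN1C(=O)CN(Cc2ccc(-c3ccc(F)c(CN4CCCCC4)n3)cc2)C1=O`) gives 0.15 h. Compound 1 (`CC(C)CN1C(=O)CN(Cc2ccc(-c3ccc(F)c(CN4CCCC(C)C4)n3)cc2)C1=O`) gives 0.1 h, and the two lie within the scatter of each other. Compound 3 (`O=C1CN(Cc2ccc(-c3cccc(CN4CCCCC4)n3)cc2)C(=O)N1C1CC1`) gives 1.42 h, beyond the scatter from compound 2, but it differs from compound 2 in more than one place, so its value does not isolate any single change.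

Compound 4 (`O=C1CN(Cc2ccc(-c3ccc(F)c(CN4CCCCC4)n3)cc2)C(=O)N1CC1CCC1`) differs from compound 2 in one place: cyclobutyl in place of isopropyl on a saturated chain carbon bound to an amide-type nitrogen in a ring. In words, cyclobutyl replaces isopropyl on a saturated chain carbon bound to an amide-type nitrogen in a ring, which also reads as isobutyl to cyclobutylmethyl. Among the measured compounds shown here, the only measured single-place step, a 1.5-fold higher number from compound 1 to compound 2 (0.18 log units; within the scatter), concerns a saturated ring carbon instead, so it is indirect evidence. For the measured compounds named here, no measured step covers this exact change, and no shift beyond the scatter is expected in this assay. The expected change is no change at the digits printed from compound 2 to compound 4 (within the scatter). Compound 4 is estimated at 0.15 h, with an expected range of 0.07 h to 0.35 h.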

Compound 4, half-life: 0.0833 h
Estimate against measurement, compound 4: 1.8-fold (0.26 log units) above, and the stated range covers the measured number.
By their numbers in this assay, from the lowest: compounds 4, 1 and 2 (each within the scatter of the next); then compound 3.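

In this assay, cyclobutyl in place of isopropyl on a saturated chain carbon bound to an amide-type nitrogen in a ring gives a 1.8-fold lower number from compound 2 to compound 4 (0.26 log units; within the scatter) and is the first single-place step at this position among the compounds shown. The earlier step concerned a saturated ring carbon, whereas this one shows that a four-membered ring of carbon only can enter here, with one more heavy atom than the group it replaces, and leave the number within the scatter. Nothing available explains this outcome.

Open, on these data alone, is whether a group of another kind on this carbon, such as an amine, a hydroxyl or a longer chain, would give a step beyond the scatter. Also open, as far as these compounds go, is whether the same change would read alike on a different core.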